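Swapping furan-2-yl for pyridin-4-yl on a brominated sulfonamide

A few compounds are considered here, and "the series" means these few. Any claim that something is new, unique, unknown or untested is made for them only; others in the source may bear on it.

- compound 1 `COc1ccc(S(=O)(=O)N2CCc3cccc(NC(=O)c4cccs4)c32)cc1` gives 31 nM
- compound 2 `COc1ccc(S(=O)(=O)N2CCc3cccc(NC(=O)c4ccncc4)c32)cc1` gives 8.8 nM
- compound 3 `COc1ccc(S(=O)(=O)N2CCc3cc(Br)cc(NC(=O)c4ccco4)c32)cc1` gives 78 nM

All three values come from a functional assay on MKN-45 cells (Homo sapiens) for cytotoxicity (on this read-out lower numbers stand for stronger inhibition and higher numbers for weaker inhibition), and compound 3 has the highest number of them, with both gaps beyond the scatter. Compound 4 `COc1ccc(S(=O)(=O)N2CCc3cc(Br)cc(NC(=O)c4ccncc4)c32)cc1` differs from compound 3 by one change, pyridin-4-yl in place of furan-2-yl on a carbonyl carbon in which pyridin-4-yl takes the place of furan-2-yl on a carbonyl carbon. The closest measured step is a 3.5-fold lower number from compound 1 to compound 2 (0.55 log units; beyond the scatter) and it brings in the same pyridin-4-yl. That step replaces thiophen-2-yl rather than furan-2-yl, however, and on a different core, so it is only an indirect guide. A modest drop to a lower number is therefore expected in this assay and the expected step is a 3.5-fold lower number from compound 3 to compound 4 (0.55 log units; beyond the scatter) in size. Compound 4 is estimated at 22 nM with an expected range of 8 nM to 60 nM for this value.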

Compound 4, half-maximal inhibitory concentration: 86 nM
Compound 4: middle estimate off by 3.9-fold (0.59 log units), on the low side; measured number outside the range, above it.
By their numbers in this assay, from the lowest: compound 2; then compound 1; then compounds 3 and 4 (each within the scatter of the next).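

In this assay, on the brominated core, pyridin-4-yl and furan-2-yl on the carbonyl carbon are not told apart, with a 1.1-fold higher number from compound 3 to compound 4 (0.04 log units; within the scatter). The change that matters here is bromo in place of hydrogen on an aromatic carbon, with a 9.8-fold higher number from compound 2 to compound 4 (0.99 log units; beyond the scatter), so the benefit seen for pyridin-4-yl without bromo does not appear with it. Nothing available accounts for this.

From the compounds shown here alone, whether chloro or an amine in place of bromo on that aromatic carbon would restore the lower number remains open. So does whether the bromo step is the same with furan-2-yl or thiophen-2-yl on the carbonyl carbon.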